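Thiazole to methylisothiazole swap in an aryl-ether imidazoline series

A few compounds are considered here, and "the series" means these few. Any claim that something is new, unique, unknown or untested is made for them only; others in the source may bear on it.

Measured compounds:
- compound 1, `c1ccc(-c2ccoc2)c(OCC2=NCCN2)c1`, gives 5.01 nM in a functional assay for activation of Alpha-1B adrenergic receptor (Homo sapiens), read by calcium flux; on this read-out lower numbers stand for an effect already at smaller amounts and higher numbers for an effect only at larger amounts of compound
- compound 2, `c1ccc(-c2nccs2)c(OCC2=NCCN2)c1`, gives 20 nM in this assay

Among the compounds with values here, compound 2 holds the higher of the two numbers so far; its nearest neighbour is compound 1, and the step of a 4.0-fold higher number from compound 1 to compound 2 (0.60 log units; beyond the scatter) lies beyond the scatter. The next compound, compound 3, `Cc1cc(-c2ccccc2OCC2=NCCN2)sn1`, departs from compound 2 by a single change: 3-methyl-1,2-thiazol-5-yl in place of 1,3-thiazol-2-yl on an aromatic carbon. Within the data shown here, no measured pair shows this particular exchange, so the only step that bears on it is the earlier one from a furan-3-yl to a 1,3-thiazol-2-yl group, a 4.0-fold higher number from compound 1 to compound 2 (0.60 log units; beyond the scatter), which was modest. Because that step a 4.0-fold higher number from compound 1 to compound 2 (0.60 log units; beyond the scatter) moved the number only moderately when one five-membered heteroaryl replaced another, a second exchange between five-membered heteroaryls of the same size class is expected to sit within or just beyond the scatter in this assay, with no strong direction. For compound 3 the estimate is 25 nM with a range of 8 nM to 80 nM, which corresponds to an expected step of a 1.3-fold higher number from compound 2 to compound 3 (0.10 log units; within the scatter).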

Compound 3, half-maximal effective concentration: < 100000 nM
Compound 3: a limit, no number; the forecaster's own chance of this, stated with the estimate: 2%; the middle value is on the limit's open side.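

In this assay compound 3 gives a limit and not a number: the limit of < 100000 nM in this assay, at which 1 of the 3 values shown sits.

Within the data shown here, no step from compound 1 or from compound 2 to compound 3 can be read from it. The compounds shown leave open where compound 3 stands in this assay, and so what 3-methyl-1,2-thiazol-5-yl in place of 1,3-thiazol-2-yl does to the number.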